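The source may report more compounds than this note shows. Statements on the series, on what has been measured and on what is new or still open speak of the compounds shown alone.

For the measured compounds named here, compound 2 `Cc1ccccc1-c1nnc(N(N)C(C)C)s1` gives, in a functional assay on the whole organism with Mus musculus as the target, with a stated time of 1 h (a lower number here means that less compound is needed, a higher number that more compound is needed for the effect), a value of 49 mg/kg; the only other measured compound, compound 1 `Cc1ccccc1-c1nnc(NN)s1`, gives 30 mg/kg, and the gap between the two lies within the scatter. Going by the values given here, the step of a 1.6-fold higher number from compound 1 to compound 2 (0.21 log units; within the scatter) is the one measured step that bears on the change to compound 3 `CNNc1nnc(-c2ccccc2C)s1`, in which ((methylamino)amino in place of amino(isopropyl)amino on an aromatic carbon). Since that step stayed within the scatter, no step beyond the scatter is expected here either. The step is expected to be a 1.2-fold lower number from compound 2 to compound 3 (0.09 log units; within the scatter). Compound 3 is therefore estimated at 40 mg/kg, with a range from 20 mg/kg to 80 mg/kg.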

Compound 3, dose for half-maximal effect: > 100 mg/kg
Compound 3: no number, only a limit; the forecaster's own chance of this, stated with the estimate: 5%; at least 2.5-fold (0.39 log units) between middle value and limit.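

Compound 3 gives no number in this assay, only a limit: the limit of > 100 mg/kg in this assay, at which 1 of the 3 values shown sits. Methyl in place of hydrogen on an amine nitrogen gives an at least 3.3-fold higher number from compound 1 to compound 3 (0.52 log units; beyond the scatter), whereas isopropyl on the nitrogen on the ring gave a step within the scatter, so at this position it matters which nitrogen carries the added group. The step of an at least 2.0-fold higher number from compound 2 to compound 3 (0.30 log units; that floor lies within the scatter) is only a floor, and it shows that the two substituted groups need not behave alike. On these data alone, whether an ethyl or an acetyl group on that amine nitrogen would behave like methyl stays open. So does the true size of both steps.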